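Replacing the Cyclopentyl Group of Compound 3

The source may hold more compounds than are shown below. What is called first, only, known or untested is meant among the compounds shown, and "the series" means these compounds.

In a functional assay on HT-29 cells (Homo sapiens) for inhibition, read by luminescence and CellTiter-Glo, with a stated time of 24 h (on this read-out lower numbers stand for an effect already at smaller amounts and higher numbers for an effect only at larger amounts of compound), compound 1 (`CCCCCn1nc(C(=O)N[C@H]2COc3ccccc3N(C)C2=S)nc1Cc1ccccc1`) gives 805 nM and compound 2 (`CN1C(=S)[C@@H](NC(=O)c2nc(Cc3ccccc3)n(CCCO)n2)COc2ccccc21`) gives 209 nM while compound 3 (`CN1C(=S)[C@@H](NC(=O)c2nc(Cc3ccccc3)n(C3CCCC3)n2)COc2ccccc21`) stands highest of the three at 3530 nM on this scale. Compound 4 (`CN1C(=S)[C@@H](NC(=O)c2nc(Cc3ccccc3)n(CC3COC3)n2)COc2ccccc21`) carries (oxetan-3-yl)methyl in place of cyclopentyl on an aromatic nitrogen. The same place was varied before: 3-hydroxypropyl to cyclopentyl gave a 17-fold higher number from compound 2 to compound 3 (1.23 log units; beyond the scatter) and pentyl to cyclopentyl gave a 4.4-fold higher number from compound 1 to compound 3 (0.64 log units; beyond the scatter) in the measurements. Both open-chain groups thus gave lower numbers than cyclopentyl, and the entering group, like 3-hydroxypropyl, contains oxygen. A modest to large drop is therefore expected in this assay and is estimated as a 5.9-fold lower number from compound 3 to compound 4 (0.77 log units; beyond the scatter) in size. For compound 4 the estimated value is 600 nM (range 180 nM to 2000 nM).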

Compound 4, half-maximal effective concentration: 2830 nM
Compound 4: middle estimate off by 4.7-fold (0.67 log units), on the low side; the measured number lies above the stated range.
By their numbers in this assay, from the lowest: compound 2; then compound 1; then compounds 4 and 3 (each within the scatter of the next).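

In this assay the oxygen of (oxetan-3-yl)methyl does not bring the low number seen with the oxygen-bearing 3-hydroxypropyl: this group and cyclopentyl cannot be told apart (a 1.2-fold lower number from compound 3 to compound 4 (0.10 log units; within the scatter)). Compound 4 stays well above both open-chain compounds (a 14-fold higher number from compound 2 to compound 4 (1.13 log units; beyond the scatter); a 3.5-fold higher number from compound 1 to compound 4 (0.55 log units; beyond the scatter)), so among these compounds both groups containing a ring give higher numbers than both open chains. Nothing measured here gives a reason for this. On these data alone, whether an amine at the end of a propyl chain would match the hydroxy group remains open, as does a longer chain ending in hydroxy.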